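The source may report more compounds than this note shows. Statements on the series, on what has been measured and on what is new or still open speak of the compounds shown alone.

The study reports two compounds with a measured result. Compound 1 `C/C(=N/O)c1ccc(NC(=O)Cn2nc(-c3ccccc3)nc2N)cc1` was tested in a functional assay on NCI-H522 cells (Homo sapiens) for inhibition, read by sulforhodamine B assay, with a stated time of 48 h, tested at 10 uM (a lower number here means less inhibition of growth, a higher number more inhibition of growth at the concentration tested), and, at the single concentration used, compound 1 gives 30%. Compound 2 `COc1ccc(-c2nc3sc(-c4ccc(Cl)cc4)cn3n2)cc1` was tested the same way, and compound 2 gives 39% in this assay; the two numbers lie within the usual scatter of each other, so no difference can be read from them.

Compound 3 `C/C(=N/O)c1ccc(NC(=O)Cn2nc(C(F)(F)F)nc2N)cc1` has not yet been measured in this assay. It differs from compound 1 in one place: trifluoromethyl in place of phenyl on an aromatic carbon. Among the measured compounds shown here, no measured pair shows what this exchange does to growth inhibition, so the expectation rests on compound 1 alone. The exchange is expected to move the result little, and the step from compound 1 to compound 3 is estimated at a number 5 percentage points lower from compound 1 to compound 3 (within the scatter), no more than the scatter. Compound 3 is therefore expected to give about 25%, in a range from 5% to 45%.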

Compound 3, percent growth inhibition at one concentration: 31%
Compound 3: the middle estimate sits 6 percentage points below what was measured; the range from low to high includes it.
By their numbers in this assay, from the lowest: compounds 1, 3 and 2 (each within the scatter of the next).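

Putting trifluoromethyl in place of phenyl on this aromatic carbon, between two ring nitrogen atoms, comes out as a number 1 percentage points higher from compound 1 to compound 3 (within the scatter) in this assay, so no change in growth inhibition can be read from this exchange. At this place, then, the six-membered aromatic ring of carbon only, with its 6 heavy atoms, is not required for the level of growth inhibition seen at the single concentration tested, since a group of 4 heavy atoms with no ring gives a result within the scatter. Nothing measured here explains why the two groups give such similar results.

On these data alone, whether an amine, a carboxylic acid or a longer alkyl chain on this carbon would leave the result where it stands remains open. Also open, as far as these compounds go, is whether any group at this position can raise growth inhibition beyond the scatter.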